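Methoxy in place of chloro at an assay limit

The compounds below may be only part of what the source reports. "The series", "measured", "known", "first", "only" and "open" are said of these compounds alone.

Compound 1 `CCOC(=O)c1c(-c2cccc(OC)c2)[nH]c2cc(OC)c(OC)cc2c1=O`: > 22000 nM, a limit
Compound 2 `CCOC(=O)c1c(-c2cccc(OC)c2)[nH]c2cc(Cl)c(Cl)cc2c1=O`: > 22000 nM, a limit

In an ADME assay on HEK293 cells (Homo sapiens) for cytotoxicity, read by luminescence, with a stated time of 72 h (on this read-out lower numbers stand for an effect already at smaller amounts and higher numbers for an effect only at larger amounts of compound), compound 2 gives > 22000 nM, which is a limit of the assay and not a number. Compound 1 gives > 22000 nM, and this too is only a limit. The two compounds therefore cannot be ranked against each other, and the whole picture so far is the limit of > 22000 nM in this assay, at which 2 of the 2 values shown sit.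

Compound 3 `CCOC(=O)c1c(-c2cccc(OC)c2)[nH]c2cc(OC)c(Cl)cc2c1=O` differs from compound 2 in one place: methoxy stands in place of chloro on an aromatic carbon, ortho to a chloro group (methoxy in place of chloro on an aromatic carbon). It thus carries both the methoxy of compound 1 and the chloro of compound 2 on the shared core. For the measured compounds named here, no measured pair shows the size of such a change, so the expectation rests on the limit shared by the two parent compounds. No step beyond the scatter is expected in this assay, in either direction, and the assay will most likely report only a limit again. The expected change is a step that the limit leaves unreadable from compound 2 to compound 3. For compound 3 the estimated value is 25000 nM, with an expected range from 12000 nM to 50000 nM.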

Compound 3, half-maximal effective concentration: > 22000 nM
Compound 3: a limit, no number; the forecaster's own chance of this, stated with the estimate: 85%; the middle value lies beyond the limit too.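

No step can be read from compound 2 to compound 3 or from compound 1 to compound 3 in this assay, because these results give no numbers to compare: the limit of > 22000 nM in this assay, at which 3 of the 3 values shown sit.

The compounds shown leave open whether exchanging methoxy and chloro on the shared core changes the result in this assay at all, and by how much.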